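Adding a methoxy to the ketone aryl of compound 3

This account rests on a few compounds, and the source may have more. Where it says the series, first, only, none or still open, it means among the compounds named here.

Of the compounds shown here, three sharing one core have been measured in a functional assay on HCT-116 cells (Homo sapiens) for cytotoxicity, read by sulforhodamine B assay, with a stated time of 48 h, tested at 10 uM; a lower number here means a stronger effect, a higher number a weaker effect of the compound at the concentration tested. Compound 1 `COc1cc(-c2cc(/C=C/C(=O)c3ccc(N)cc3)[nH]n2)cc(OC)c1OC` gives -78%, compound 2 `COc1cc(-c2cc(/C=C/C(=O)c3ccc(Cl)c(Cl)c3)[nH]n2)cc(OC)c1OC` gives 16%, and compound 3 `COc1ccc(C(=O)/C=C/c2cc(-c3cc(OC)c(OC)c(OC)c3)n[nH]2)cc1OC` gives -65%. On these three numbers compound 3 stands second highest; the nearest is compound 1, with a number 13 percentage points higher from compound 1 to compound 3 (beyond the scatter), and the furthest is compound 2, with a number 81 percentage points lower from compound 2 to compound 3 (beyond the scatter). The remaining step, a number 94 percentage points higher from compound 1 to compound 2 (beyond the scatter), is the largest of the three.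

Compound 4 `COc1cc(C(=O)/C=C/c2cc(-c3cc(OC)c(OC)c(OC)c3)n[nH]2)cc(OC)c1OC` differs from compound 3 by methoxy in place of hydrogen on an aromatic carbon. For the measured compounds named here, each measured step changes the aryl group on the carbonyl carbon, but none of them adds a methoxy to a ring that already carries two, so no step matches this change directly. The step from compound 1 to compound 3 shows that exchanging one oxygen- or nitrogen-bearing aryl for another moves this assay only modestly, whereas the large steps both involve the dichlorophenyl of compound 2. Compound 4 is therefore expected to stay close to compound 3, with a step of a number 5 percentage points higher from compound 3 to compound 4 (within the scatter) that may fall within the scatter. The estimate for compound 4 in this assay is -60%, with a range from -85% to -20%.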

Compound 4, a percentage reported as activity, at one concentration (the size of the read-out at that concentration, not a potency): -99%
The estimate for compound 4 lay 39 percentage points above the measured number; the measured number lies below the stated range.
By their numbers in this assay, from the lowest: compound 4; then compound 1; then compound 3; then compound 2.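

In this assay, the added methoxy sits on an aromatic carbon ortho to a methoxy group and meta to a large group, and it gives a number 34 percentage points lower from compound 3 to compound 4 (beyond the scatter), so a single small substituent at this position changes the read-out beyond the scatter. The earlier steps shown here replaced the whole aryl group on the carbonyl carbon, and the one between two electron-rich-looking partners, a number 13 percentage points higher from compound 1 to compound 3 (beyond the scatter), gave no sign that a change of one methoxy on an already substituted ring could matter this much. Nothing available here explains why this methoxy has such an effect on the cells.

What remains open is whether the step belongs to methoxy itself or to any group at this place, since the shown compounds leave the outcome with a hydroxyl, an ethoxy or a fluorine atom there unknown. Each read-out also comes from one concentration, so the compounds shown say nothing yet about how potency changes with this added methoxy.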